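The compounds below may be only part of what the source reports. "The series", "measured", "known", "first", "only" and "open" are said of these compounds alone.

In a functional assay on MCF7 cells (Homo sapiens) for cytotoxicity (on this read-out lower numbers stand for stronger inhibition and higher numbers for weaker inhibition), compound 1 `CS(=O)(=O)c1ccc2nc(NC(=O)CCCCCCC(=O)NO)sc2c1` gives 15.4 ug/mL and compound 3 `CCOc1ccc2nc(NC(=O)CCCCC(=O)NO)sc2c1` gives 8.72 ug/mL. Among the compounds with values here, these are the only two exact numbers, and they lie within the scatter of each other. Compound 2 `CS(=O)(=O)c1ccc2nc(NC(=O)CCCCC(=O)NO)sc2c1` is reported only as a limit, > 30 ug/mL.

The next structure is compound 4 `COc1ccc2nc(NC(=O)CCCCCCC(=O)NO)sc2c1`, with the change methoxy in place of methylsulfonyl on an aromatic carbon. The closest measured precedent is an at least 3.4-fold lower number from compound 2 to compound 3 (0.53 log units; beyond the scatter), where ethoxy takes the place of methylsulfonyl on an aromatic carbon. Its size is only a floor, since it starts from a limit. The other measured step, an at least 1.9-fold higher number from compound 1 to compound 2 (0.28 log units; that floor lies within the scatter), alters the chain instead, and its floor stays within the scatter. The exchange has not been measured on the chain of compound 1, so its transfer is uncertain. A modest move towards a lower number is therefore expected in this assay, and the expected step is a 3.1-fold lower number from compound 1 to compound 4 (0.49 log units; beyond the scatter). For compound 4 the estimated value is 5 ug/mL, with an expected range of 1.6 ug/mL to 15 ug/mL.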

Compound 4, half-maximal inhibitory concentration: 1.85 ug/mL
Beside the measured number, compound 4's estimate is 2.7-fold (0.43 log units) above it; the range from low to high includes it.
By their numbers in this assay, from the lowest: compound 4; then compounds 3 and 1 (each within the scatter of the next). At a limit, above all of these: compound 2.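

In this assay, an 8.3-fold lower number from compound 1 to compound 4 (0.92 log units; beyond the scatter) gives the first exact size for the loss of methylsulfonyl from this aromatic carbon, and that size lies beyond the scatter. The earlier exchange on the shorter chain, an at least 3.4-fold lower number from compound 2 to compound 3 (0.53 log units; beyond the scatter), runs in the same direction with ethoxy entering, so the lower number now appears on both chains shown, and no compound shown goes against it. The size of that earlier step remains a floor, and the value of compound 2 is a limit and not a number: the limit of > 30 ug/mL in this assay, at which 1 of the 4 values shown sits.

Methoxy and ethoxy stand on different chains here, and the compounds shown do not rank one against the other. From the compounds shown here alone, how an amine or a carboxylic acid on this aromatic carbon would read, on either chain, stays open.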